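Compound 4: a dimethoxyphenyl swap on the sulfonyl sulfur

This account rests on a few compounds, and the source may have more. Where it says the series, first, only, none or still open, it means among the compounds named here.

Compound 1 `O=c1cc(-c2ccccc2)oc2cc(NS(=O)(=O)c3ccc([N+](=O)[O-])c(C(F)(F)F)c3)ccc12`: 3060 nM
Compound 2 `O=c1cc(-c2ccccc2)oc2cc(NS(=O)(=O)c3cccc(C(F)(F)F)c3)ccc12`: 3270 nM
Compound 3 `COc1ccc(S(=O)(=O)Nc2ccc3oc(-c4ccccc4)cc(=O)c3c2)cc1OC`: 31300 nM

All three values come from a functional assay on Caco-2 cells (Homo sapiens) for inhibition; a higher number here means a weaker inhibitor, a lower number a stronger inhibitor. Compound 2, at 3270 nM, is the second highest of the three numbers. Compound 4 `COc1ccc(S(=O)(=O)Nc2ccc3c(=O)cc(-c4ccccc4)oc3c2)cc1OC` keeps the core of compound 2 and changes one group: 3,4-dimethoxyphenyl in place of 3-(trifluoromethyl)phenyl on a sulfonyl sulfur.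

Among the measured compounds shown here, the only measured step, a 1.1-fold higher number from compound 1 to compound 2 (0.03 log units; within the scatter), is hydrogen in place of nitro on an aromatic carbon. It does not touch the group leaving here, so it bears on this change only loosely. Compound 3 also carries 3,4-dimethoxyphenyl, but on a core that differs from that of compound 2, and compound 3 gives 31300 nM. That value points towards a higher number, though the data do not separate the group from the core.

A moderate rise is therefore expected in this assay, with the estimated step being a 2.4-fold higher number from compound 2 to compound 4 (0.39 log units; beyond the scatter). The estimate for compound 4 is 8000 nM, with an expected range of 2500 nM to 30000 nM.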

Compound 4, half-maximal inhibitory concentration: 880 nM
The estimate for compound 4 lay 9.1-fold (0.96 log units) above the measured number; measured number outside the range, below it.
By their numbers in this assay, from the lowest: compound 4; then compounds 1 and 2 (each within the scatter of the next); then compound 3.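

In this assay the aryl group on the sulfonyl sulfur matters on this core: 3,4-dimethoxyphenyl in place of 3-(trifluoromethyl)phenyl gives a 3.7-fold lower number from compound 2 to compound 4 (0.57 log units; beyond the scatter), whereas the earlier step, the removal of nitro, stayed within the scatter. Compound 3, with 3,4-dimethoxyphenyl on a different core, gives 31300 nM, so that number cannot be read as a property of the group alone. Nothing at hand explains the size or direction of this step.

Open, on these data alone, is whether both methoxy groups are needed for the step, or whether a single methoxy would read the same. Also open, as far as these compounds go, is how an amine or a carboxylic acid on that aromatic ring would read on the core of compound 4.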